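The compounds below may be only part of what the source reports. "The series", "measured", "known", "first", "only" and "open" are said of these compounds alone.

Compound 1 `CCCC(C#CC(=O)OC)O/C=C/C(=O)OC` gives 270 nM in a functional assay on HBL-100 cells (Homo sapiens) for antiproliferative activity, read by sulforhodamine B assay, with a stated time of 48 h (a lower number here means a stronger inhibitor of growth, a higher number a weaker inhibitor of growth), while compound 2 `COC(=O)C#CC(CC(C)C)O/C=C/C(=O)OC` gives 330 nM in this assay; the two are not separated beyond the scatter, as a 1.2-fold higher number from compound 1 to compound 2 (0.09 log units; within the scatter) shows. Compound 3 `CCCCCCCCCCC(C#CC(=O)OC)O/C=C/C(=O)OC` differs from compound 1 by heptyl in place of hydrogen on a saturated chain carbon, four bonds along the chain from an oxygen on an unsaturated carbon and a triple-bonded carbon. Among the measured compounds shown here, the only measured step that bears on this, methyl in place of hydrogen on a saturated chain carbon, a 1.2-fold higher number from compound 1 to compound 2 (0.09 log units; within the scatter), lay within the scatter and is a much smaller change than heptyl, so no step beyond the scatter is expected, with some room for a higher number. Compound 3 is therefore estimated at 400 nM, between 150 nM and 1200 nM, an expected 1.5-fold higher number from compound 1 to compound 3 (0.17 log units; within the scatter).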

Compound 3, concentration for 50% growth inhibition: 2200 nM
Compound 3: the middle estimate sits 5.5-fold (0.74 log units) below what was measured; measured number outside the range, above it.
By their numbers in this assay, from the lowest: compounds 1 and 2 (each within the scatter of the next); then compound 3.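

Unlike the small methyl addition (a 1.2-fold higher number from compound 1 to compound 2 (0.09 log units; within the scatter)), the heptyl addition at this saturated chain carbon produces a step beyond the scatter in this assay (an 8.1-fold higher number from compound 1 to compound 3 (0.91 log units; beyond the scatter)). Across these three compounds, then, this position accepts the small change without a clear shift, while the much longer chain weakens growth inhibition. Nothing available accounts for this loss. Still open, as far as these compounds go, is how the number moves with chains of intermediate length, and whether a long chain ending in an amine or a carboxylic acid would behave like heptyl.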